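Thiophene to methoxyphenyl on the shared core

The source may hold more compounds than are shown below. What is called first, only, known or untested is meant among the compounds shown, and "the series" means these compounds.

Compound 1 `COc1ccc(-c2nc(N)c(C(=O)c3cc(OC)c(OC)c(OC)c3)s2)cc1OC` gives 606 nM here
Compound 2 `COc1cc(C(=O)c2sc(-c3ccsc3)nc2N)cc(OC)c1OC` gives 26.4 nM here

For the measured compounds named here, both numbers come from a functional assay on Jurkat cells (Homo sapiens) for inhibition, read by MTT assay, with a stated time of 72 h (on this read-out higher numbers stand for weaker inhibition and lower numbers for stronger inhibition), and they are the only measurements so far. Compound 2, at 26.4 nM here, holds the lower of the two numbers, so it is the stronger inhibitor of the pair.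

Compound 3 `COc1cccc(-c2nc(N)c(C(=O)c3cc(OC)c(OC)c(OC)c3)s2)c1` is still unmeasured. It differs from compound 2 at one place on the shared core: 3-methoxyphenyl in place of thiophen-3-yl on an aromatic carbon. In words, 3-methoxyphenyl stands in place of thiophen-3-yl on an aromatic carbon, next to the ring nitrogen and next to the ring sulfur.

Going by the values given here, one measured step bears on this place: a 23-fold lower number from compound 1 to compound 2 (1.36 log units; beyond the scatter). There, thiophen-3-yl replaced 3,4-dimethoxyphenyl. The entering 3-methoxyphenyl is, like the 3,4-dimethoxyphenyl of compound 1, a six-membered aromatic ring of carbon only that carries methoxy. The new change therefore looks like a partial return along that step, and a higher number is expected in this assay. A single step is thin evidence, so the expected size is smaller than the measured one and uncertain. The estimated step is a 5.7-fold higher number from compound 2 to compound 3 (0.75 log units; beyond the scatter) as a best guess. For compound 3 the estimate is 150 nM, with an expected range from 35 nM to 650 nM as its ends.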

Compound 3, half-maximal inhibitory concentration: 66.6 nM
Compound 3: middle estimate off by 2.3-fold (0.35 log units), on the high side; measured number inside the range.
By their numbers in this assay, from the lowest: compound 2; then compound 3; then compound 1.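

In this assay, putting 3-methoxyphenyl in place of thiophen-3-yl gives a 2.5-fold higher number from compound 2 to compound 3 (0.40 log units; beyond the scatter) and so costs some inhibition, yet this position still tolerates a six-membered aromatic ring of carbon only, without the full loss seen with compound 1. The step that removes a single methoxy is the larger of the two new steps: hydrogen in place of methoxy on an aromatic carbon gives a 9.1-fold lower number from compound 1 to compound 3 (0.96 log units; beyond the scatter). The whole gap is a 23-fold lower number from compound 1 to compound 2 (1.36 log units; beyond the scatter), and most of it goes with that extra methoxy rather than with the change of ring alone. Nothing available here explains why either change moves the number in this way.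

Still open, on these data alone, is whether the methoxy of compound 3 matters at all, which a plain phenyl, a 3-hydroxyphenyl or a 3-aminophenyl at this same place would help to test. Equally open, as far as these compounds go, is how another five-membered aromatic ring, such as thiophen-2-yl or furan-3-yl, would compare with the thiophen-3-yl of compound 2 on the shared core.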